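Replacing the Indazolyl Group of Compound 1

This account rests on a few compounds, and the source may have more. Where it says the series, first, only, none or still open, it means among the compounds named here.

Going by the values given here, compound 1 `CC/C(=C(/c1ccc(/C=C/C(=O)O)cc1)c1ccc2[nH]ncc2c1)c1ccccc1` is the only compound here with an actual number. In a functional assay on MCF7 cells (Homo sapiens) for antiproliferative activity, read by CellTiter-Glo, with a stated time of 5 days (on this read-out lower numbers stand for stronger inhibition and higher numbers for weaker inhibition), compound 1 gives 7.2 nM. Compound 2 `CC/C(=C(/c1ccc(/C=C/C(=O)O)cc1)c1ccn2nncc2c1)c1ccccc1` is reported only as a limit of the assay: in this assay compound 2 gives > 500 nM. The step of an at least 69-fold higher number from compound 1 to compound 2 (1.84 log units; beyond the scatter) therefore runs to the limit of > 500 nM in this assay, at which 1 of the 2 values shown sits. Compound 3 `CC/C(=C(/c1ccc(/C=C/C(=O)O)cc1)c1ccc2nnnn2c1)c1ccccc1` carries a related change: a group of 9 heavy atoms (5 carbon, 4 nitrogen; one five-membered aromatic ring with 4 hetero atoms, one six-membered aromatic ring with 1 hetero atom) in place of a group of 9 heavy atoms (7 carbon, 2 nitrogen; one five-membered aromatic ring with 2 hetero atoms, one six-membered aromatic ring of carbon only), on a double-bonded chain carbon bound to an aromatic carbon and a double-bonded chain carbon. Among the compounds with values here, only the step from compound 1 to compound 2 bears on this, and it was large, so a large weakening is expected. Compound 3 is expected to give 1500 nM, within 300 nM to 8000 nM, an expected step of a 210-fold higher number from compound 1 to compound 3 (2.32 log units; beyond the scatter).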

Compound 3, half-maximal inhibitory concentration: > 500 nM
Compound 3: only a limit was reported; the forecaster's own chance of this, stated with the estimate: 80%; the middle value lies beyond the limit too.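

Compound 3 gives a second replacement for the 1H-indazol-5-yl group at this position, again with a six-membered aromatic ring with 1 hetero atom, and the result is an at least 69-fold higher number from compound 1 to compound 3 (1.84 log units; beyond the scatter). Compound 3 also ends at a limit of the assay, not a number: the limit of > 500 nM in this assay, at which 2 of the 3 values shown sit. The step from compound 2 to compound 3 cannot be read, since both values are limits.

The entering group of compound 3 has 0 hydrogen-bond donors against 1 in compound 1. On these data alone, whether a group such as 1H-benzotriazol-5-yl or 1H-indol-5-yl would keep the activity of compound 1 remains open.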